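The source may hold more compounds than are shown below. What is called first, only, known or untested is meant among the compounds shown, and "the series" means these compounds.

In a functional assay on A-375 cells (Homo sapiens) for cytotoxicity, read by CCK-8 assay, with a stated time of 24 h (a higher number here means a weaker inhibitor, a lower number a stronger inhibitor), compound 1 `COc1ccccc1Oc1c(N)nc(-c2ccccc2)nc1Cl`, with a plain phenyl ring on the shared core, gives 7220 nM. Compound 2 `COc1ccccc1Oc1c(N)nc(-c2cccc(C)c2)nc1Cl`, which carries 3-methylphenyl instead, gives 65300 nM, and that change is a 9.0-fold higher number from compound 1 to compound 2 (0.96 log units; beyond the scatter).

Compound 3 `COc1ccccc1Oc1c(N)nc(-c2ccc(C)cc2)nc1Cl`, which carries 4-methylphenyl, reaches only a limit of the assay, > 80000 nM, and not a true number. The move to compound 3 from the plain ring is an at least 11-fold higher number from compound 1 to compound 3 (1.04 log units; beyond the scatter). The comparison between the two methyl compounds is an at least 1.2-fold higher number from compound 2 to compound 3 (0.08 log units; that floor lies within the scatter), so the data do not separate them. Both methyl compounds thus sit well on the weak side of compound 1.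

Compound 4 `COc1cccc(-c2nc(N)c(Oc3ccccc3OC)c(Cl)n2)c1` changes that same ring: 3-methoxyphenyl in place of 4-methylphenyl on an aromatic carbon. No methoxy group has been measured in this series, so the nearest guide is compound 2, whose group carries the same number in its name and which gives 65300 nM. Compound 4 is therefore expected to stay weak, far closer to the methyl compounds than to compound 1, perhaps with a somewhat lower number than the limit. The expected change is an at least 1.7-fold lower number from compound 3 to compound 4 (0.24 log units; that floor lies within the scatter). For compound 4 the estimated value is 45000 nM, with an expected range of 14000 nM to 80000 nM.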

Compound 4, half-maximal inhibitory concentration: 24600 nM
The estimate for compound 4 lay 1.8-fold (0.26 log units) above the measured number; low and high end bracket the measured number.
By their numbers in this assay, from the lowest: compound 1; then compound 4; then compound 2. At a limit, above all of these: compound 3.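

In this assay, compound 4 shows that a substituent on this phenyl ring need not cost as much as methyl does: the step from the 3-methyl to the 3-methoxy ring is a 2.7-fold lower number from compound 2 to compound 4 (0.42 log units; beyond the scatter), so the group at this ring carbon changes the number even when the ring position stays the same. The plain ring still keeps the lowest number, with a 3.4-fold higher number from compound 1 to compound 4 (0.53 log units; beyond the scatter), so all three substituted rings shown, compounds 2, 3 and 4, stand on the weak side of compound 1, and none of them goes against this. The step of an at least 3.2-fold lower number from compound 3 to compound 4 (0.51 log units; beyond the scatter) changes both the group and its ring position and gives only a floor, because compound 3 stands at a limit and not at a true number: the limit of > 80000 nM in this assay, at which 1 of the 4 values shown sits.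

Whether 4-methoxyphenyl would also improve on 4-methylphenyl stays open, so the compounds shown do not separate the effect of the group from that of its ring position. Also open, on these data alone, is whether a hydroxy group or an amine on this ring could bring the number back to that of compound 1 or lower.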